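This account rests on a few compounds, and the source may have more. Where it says the series, first, only, none or still open, it means among the compounds named here.

Measured compounds in an assay on isolated protein for inhibition of Polyunsaturated fatty acid 5-lipoxygenase (Homo sapiens), read by HPLC, with a stated time of 10 min; on this read-out lower numbers stand for stronger inhibition and higher numbers for weaker inhibition:

compound 1, `Cc1cc(NC(=O)Nc2ccccc2)ccc1OCc1nc2ccccc2s1`, 2070 nM
compound 2, `Cc1cc(NC(=O)Nc2ccc(Cl)c(Cl)c2)ccc1OCc1nc2ccccc2s1`, 2170 nM
compound 3, `Cc1cc(NC(=O)Nc2ccccc2Cl)ccc1OCc1nc2ccccc2s1`, 680 nM

Compound 3 gives the lowest number of the three, and its steps to the others are beyond the scatter: a 3.0-fold lower number from compound 1 to compound 3 (0.48 log units; beyond the scatter) and a 3.2-fold lower number from compound 2 to compound 3 (0.50 log units; beyond the scatter). Compound 4, `O=C(Nc1ccc(OCc2nc3ccccc3s2)cc1)Nc1ccccc1Cl`, differs from compound 3 by hydrogen in place of methyl on an aromatic carbon. Going by the values given here, none of the measured steps touches this methyl; all three concern the phenyl on the urea nitrogen, so no measured step bears directly on it. With nothing to point either way, compound 4 is expected to stay close to compound 3, with at most a small shift, a 1.5-fold higher number from compound 3 to compound 4 (0.17 log units; within the scatter). The estimate for compound 4 in this assay is 1000 nM, within 350 nM to 3000 nM.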

Compound 4, half-maximal inhibitory concentration: 360 nM
For compound 4 the middle estimate is 2.8-fold (0.44 log units) above the measured one; measured number inside the range.
By their numbers in this assay, from the lowest: compounds 4 and 3 (each within the scatter of the next); then compounds 1 and 2 (each within the scatter of the next).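

In this assay, hydrogen in place of methyl gives a 1.9-fold lower number from compound 3 to compound 4 (0.28 log units; within the scatter). Going by these compounds alone, this is the first measured change outside the phenyl on the amide-type nitrogen, and it shows that compound 3 and compound 4 stay within the scatter of each other with or without the methyl on this aromatic carbon. Nothing at hand explains this result. Still open, as far as these compounds go, is how an ethyl or a methoxy on this carbon would read, and whether the same change gives a similar step with the unsubstituted phenyl of compound 1.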